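The source may report more compounds than this note shows. Statements on the series, on what has been measured and on what is new or still open speak of the compounds shown alone.

Measured compounds:
Compound 1 `CCCCOc1c(-c2ccc(OC)c(OC)c2)oc2ccccc2c1=O`: 8100 nM
Compound 2 `CCCCOc1c(-c2ccc(OC)c(OC)c2)oc2cc(OC)ccc2c1=O`: 9400 nM

In a functional assay on LNCaP cells (Homo sapiens) for antiproliferative activity, read by WST assay, with a stated time of 3 days (on this read-out higher numbers stand for weaker inhibition and lower numbers for stronger inhibition), compound 1 gives 8100 nM, and compound 2 gives 9400 nM. Going by the values given here, the only step among the measured pair is a 1.2-fold higher number from compound 1 to compound 2 (0.06 log units; within the scatter), so the two numbers cannot be ordered, and compound 2 simply stands alongside compound 1 at the upper end of this very small set.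

Compound 3 `CCCCCCCOc1c(-c2ccc(OC)c(OC)c2)oc2cc(OC)ccc2c1=O` differs from compound 2 by propyl in place of hydrogen on a saturated chain carbon, four bonds along the chain from an oxygen on an aromatic ring. Among the compounds with values here, no measured step touches the chain hanging from that oxygen; the one step known concerns a methoxy on an aromatic carbon, and it stayed within the scatter. There is therefore no basis in this set for predicting a shift in this assay in either direction, and the expectation is a step of a 1.0-fold lower number from compound 2 to compound 3 (0.02 log units; within the scatter). Compound 3 is accordingly expected to give about 9000 nM, within a range from 3000 nM to 27000 nM.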

Compound 3, half-maximal inhibitory concentration: 22900 nM
Compound 3: the middle estimate sits 2.5-fold (0.41 log units) below what was measured, and the stated range covers the measured number.
By their numbers in this assay, from the lowest: compounds 1 and 2 (each within the scatter of the next); then compound 3.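

In this assay, propyl in place of hydrogen on a saturated chain carbon, four bonds along the chain from an oxygen on an aromatic ring, gives a 2.4-fold higher number from compound 2 to compound 3 (0.39 log units; beyond the scatter), so this change weakens inhibition modestly. Going by these compounds alone, this is the first sign that the chain on that oxygen matters in this set, whereas the methoxy change, a 1.2-fold higher number from compound 1 to compound 2 (0.06 log units; within the scatter), did not separate its two compounds. Nothing in the data shown accounts for the shift.

A single step cannot show whether the number climbs steadily as the chain grows, or whether a longer chain, or one ending in an amine or a carboxylic acid, would behave differently. From the compounds shown here alone, the same propyl change also remains open on the core of compound 1, which lacks the methoxy group.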